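Trimming an Ethyl to a Methyl on an Inactive Core

The compounds below may be only part of what the source reports. "The series", "measured", "known", "first", "only" and "open" are said of these compounds alone.

Compound 1, `Cc1nc(C(C)C)n2c(O)nnc(-c3ccccc3)c12`: > 48000 nM
Compound 2, `CCc1nc(C)c2cnnc(SC)n12`: > 48000 nM

In a functional assay for inhibition, with Homo sapiens as the target (a higher number here means a weaker inhibitor, a lower number a stronger inhibitor), compound 2 gives > 48000 nM, which is a limit of the assay rather than a number. Compound 1 likewise gives > 48000 nM, also a limit. the limit of > 48000 nM in this assay, at which 2 of the 2 values shown sit: every reading here sits at that limit. Compound 3, `CSc1nncc2c(C)nc(C)n12`, differs from compound 2 by hydrogen in place of methyl on a saturated chain carbon bound to an aromatic carbon; one bond further out, this reads as ethyl to methyl. Going by the values given here, no measured step exists, and a change this small is expected to move the reading by no more than the scatter, so the expected step is a step that the limit leaves unreadable from compound 2 to compound 3. Compound 3 is therefore expected to give 80000 nM, within 30000 nM to 300000 nM.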

Compound 3, half-maximal inhibitory concentration: > 48000 nM
Compound 3 gave a limit, no number (the forecaster's own chance of this, stated with the estimate: 85%); the middle value is on the limit's open side.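

No step can be read between compound 2 and compound 3: each gives only a limit in this assay, not a number. From the compounds shown here alone, whether ethyl to methyl changes inhibition at all, and which compound would give a readable value, stays open.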